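The source may hold more compounds than are shown below. What is called first, only, known or untested is meant among the compounds shown, and "the series" means these compounds.

Working notes on the series. Compound 1 `COc1cc(OC)cc(C(=O)Nc2cc(-c3ccccc3)nn2-c2ccccc2)c1` gives in an assay on HEK293 cells for displacement of a labelled ligand from metabotropic glutamate receptor 5 (Rattus norvegicus) (on this read-out higher numbers stand for weaker inhibition and lower numbers for stronger inhibition), only a limit of the assay, > 10000 nM. For the measured compounds named here, compound 2 `O=C(Nc1cc(-c2ccccc2)nn1-c1ccccc1Br)c1ccccc1` is the one compound with a number in this assay, 2600 nM. The other value shown, that of compound 1, is a limit (the limit of > 10000 nM in this assay, at which 1 of the 2 values shown sits). Going by the values given here, no step between measured compounds is available, so nothing measured sets the size of the next change. Compound 3 `COc1cccc(-n2nc(-c3ccccc3)cc2NC(=O)c2ccccc2)c1` differs from compound 2 by 3-methoxyphenyl in place of 2-bromophenyl on an aromatic nitrogen. Among the compounds with values here, with no measured step to rest on, the change from compound 2 to compound 3 is expected to stay within the scatter, a 1.2-fold higher number from compound 2 to compound 3 (0.06 log units; within the scatter). Compound 3 is therefore estimated at 3000 nM in this assay, between 800 nM and 12000 nM.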

Compound 3, inhibition constant: 2100 nM
For compound 3 the middle estimate is 1.4-fold (0.15 log units) above the measured one; the range from low to high includes it.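

On the aromatic nitrogen, next to the ring atom that bears a benzamido group, the change gives in this assay a 1.2-fold lower number from compound 2 to compound 3 (0.09 log units; within the scatter). This position therefore accepts either aryl group without a change beyond the scatter, although 3-methoxyphenyl carries a hydrogen-bond acceptor and 2-bromophenyl carries none. No measured property accounts for this result.

On these data alone, the effect of the substituent's ring place, apart from the substituent itself, stays open. So does the outcome of an amine or a carboxylic acid on this aryl ring, or of a longer alkyl chain in place of the ring.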